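Resolving One Stereocentre of Compound 1

A few compounds are considered here, and "the series" means these few. Any claim that something is new, unique, unknown or untested is made for them only; others in the source may bear on it.

Measured so far in an assay on isolated protein for inhibition of retinal dehydrogenase 2 (Homo sapiens); on this read-out lower numbers stand for stronger inhibition and higher numbers for weaker inhibition:
compound 1, `CC(Sc1nc2c(cnn2C)c(=O)n1-c1ccccc1)c1ccccc1`, 110 nM
compound 2, `COc1ccccc1C(C)Sc1nc2c(cnn2C)c(=O)n1-c1ccccc1`, 136 nM
compound 3, `CC(Sc1nc2c(cnn2C)c(=O)n1-c1ccc(C#N)cc1)c1ccccc1`, 3100 nM

Compound 1 holds the lowest of the three numbers. Its nearest neighbour is compound 2, reached by a 1.2-fold higher number from compound 1 to compound 2 (0.09 log units; within the scatter). The furthest is compound 3, reached by a 28-fold higher number from compound 1 to compound 3 (1.45 log units; beyond the scatter). Both measured steps change a hydrogen on an aromatic carbon and leave the saturated chain carbon drawn without configuration.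

Compound 4, `C[C@@H](Sc1nc2c(cnn2C)c(=O)n1-c1ccccc1)c1ccccc1`, differs from compound 1 only in that respect: the two compounds have the same atoms and bonds; at least one stereo element is drawn with a configuration in one of them and without one in the other: 1 of 1 stereo elements differ; a stereocentre at a saturated chain carbon is drawn without a configuration in compound 1 and R in compound 4. Among the measured compounds shown here, no measured pair differs solely in the drawn configuration at that carbon, so neither step to compound 2 nor to compound 3 bears directly on this change. Since compound 1 is drawn without configuration, its number may combine both configurations, and compound 4 could sit on either side of it. With nothing to point one way, the expected step of a 1.4-fold lower number from compound 1 to compound 4 (0.14 log units; within the scatter) is none beyond the scatter. Compound 4 is therefore estimated at 80 nM in this assay, within 30 nM to 400 nM.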

Compound 4, half-maximal inhibitory concentration: 40 nM
Compound 4: the middle estimate sits 2.0-fold (0.30 log units) above what was measured; low and high end bracket the measured number.
By their numbers in this assay, from the lowest: compound 4; then compounds 1 and 2 (each within the scatter of the next); then compound 3.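

In this assay, among the compounds shown here, the saturated chain carbon proves to be a place where the number responds, which the earlier steps on aromatic carbons could not show: the R configuration gives a 2.8-fold lower number from compound 1 to compound 4 (0.44 log units; beyond the scatter). The step is modest in size, yet it comes without any change in atoms or bonds. It can be tied to the drawn stereochemistry at this carbon, because nothing else separates the two compounds: the fact that one of compounds 1 and 4 is drawn with a defined configuration and the other without, at the place where they differ

The compounds shown leave open how the S configuration at this carbon compares with R, and so what compound 1 holds behind its single number. They also leave open whether the R preference would persist with an ethyl group or a carboxylic acid on the same saturated chain carbon.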